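Bromo on the benzylidene ring of compound 2

The compounds below may be only part of what the source reports. "The series", "measured", "known", "first", "only" and "open" are said of these compounds alone.

The account opens with compound 1 `O=C1CS/C(=N\c2csc(-c3ccccc3)c2)N1` and compound 2 `O=C1N/C(=N/c2csc(-c3ccc(Cl)cc3)c2)S/C1=C\c1ccccc1`, two compounds sharing a core, and with the assay a functional assay on MDA-MB-231 cells (Homo sapiens) for cytotoxicity, read by MTT assay, with a stated time of 72 h; on this read-out lower numbers stand for stronger inhibition and higher numbers for weaker inhibition. In this assay compound 1 gives only a limit, > 50000 nM, not a number. Compound 2 gives 18000 nM, which is the only number shown in this assay. The other value, that of compound 1, is a limit (the limit of > 50000 nM in this assay, at which 1 of the 2 values shown sits). Going by the values given here, no step between measured compounds is available, so nothing here shows how much a single change on the shared core shifts the read-out in this assay.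

The next compound is compound 3 `O=C1N/C(=N/c2csc(-c3ccc(Cl)cc3)c2)S/C1=C\c1ccc(Br)cc1`. It differs from compound 2 in one place: bromo in place of hydrogen on an aromatic carbon, on an aromatic carbon of a six-membered aromatic ring of carbon only, so that phenyl becomes 4-bromophenyl. Among the compounds with values here, with no measured step to lean on, the step of a 1.5-fold lower number from compound 2 to compound 3 (0.18 log units; within the scatter) is expected to be small, a modest gain at most, and not clearly beyond the usual scatter. For compound 3 the expected value in this assay is therefore 12000 nM, with a range from 4000 nM to 40000 nM.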

Compound 3, half-maximal inhibitory concentration: 3500 nM
Beside the measured number, compound 3's estimate is 3.4-fold (0.54 log units) above it, outside the stated range (below it).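

Going by these compounds alone, this step gives the first measured size for a single change on the shared core: in this assay, bromo in place of hydrogen on an aromatic carbon brings a 5.1-fold lower number from compound 2 to compound 3 (0.71 log units; beyond the scatter) and, unlike anything the earlier compounds could show, this is a shift beyond the usual scatter. The place in question, on a six-membered aromatic ring of carbon only and para to a large group, is therefore one where the read-out responds to a small change, here one bromine that adds no ring, no hydrogen-bond donor or acceptor and no net charge. The compounds shown give no measurement that accounts for why this change moves the number.

From the compounds shown here alone, it remains open whether the shift belongs to bromo in particular, or whether a chloro, a methoxy or an amine at the same place would give a step of similar size. Going by these compounds, it is also open whether the same change carries over to other members, and how a carboxylic acid or a longer chain at this place would read in this assay as well.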